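Naphthalen-1-yl on the methyl group of compound 1

The compounds below may be only part of what the source reports. "The series", "measured", "known", "first", "only" and "open" are said of these compounds alone.

compound 1 `Cc1ccc(S(=O)(=O)Oc2ccccc2/C=C(\C#N)C(=O)Nc2nnc(C)s2)cc1` gives 78%
compound 2 `Cc1ccc(S(=O)(=O)Oc2cccc(/C=C(\C#N)C(=O)Nc3nnc(-c4ccccc4Cl)s3)c2)cc1` gives 67%
compound 3 `Cc1ccc(S(=O)(=O)Oc2cccc(/C=C(\C#N)C(=O)Nc3nnc(-c4cccs4)s3)c2)cc1` gives 62%

In a functional assay on HL-60 cells (Homo sapiens) for inhibition, read by CCK-8 assay, with a stated time of 48 h, tested at 20 uM (on this read-out lower numbers stand for less inhibition of growth and higher numbers for more inhibition of growth at the one concentration tested), compound 1 stands highest of the three at 78% with both others beyond the scatter under it. Compound 4 `Cc1ccc(S(=O)(=O)Oc2ccccc2/C=C(\C#N)C(=O)Nc2nnc(Cc3cccc4ccccc34)s2)cc1` carries naphthalen-1-yl in place of hydrogen on a saturated chain carbon bound to an aromatic carbon in the form of naphthalen-1-yl in place of hydrogen on a saturated chain carbon bound to an aromatic carbon, that is methyl to (naphthalen-1-yl)methyl. For the measured compounds named here, no measured step shows this change directly. Going by the values given here, the one step available, a number 5 percentage points lower from compound 2 to compound 3 (within the scatter) between two aromatic groups, stays within the scatter and says little here. Compound 2 at 67% and compound 3 at 62% bear aromatic groups instead of the methyl of compound 1 but also differ from it elsewhere in the core. A moderate fall is therefore expected, with a number 12 percentage points lower from compound 1 to compound 4 (beyond the scatter) as the estimated step in this assay for now. For compound 4 the estimated value is 66% with 48% to 82% as the expected range.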

Compound 4, percent growth inhibition at one concentration: 19%
Compound 4: middle estimate off by 47 percentage points, on the high side; the measured number lies below the stated range.
By their numbers in this assay, from the lowest: compound 4; then compounds 3 and 2 (each within the scatter of the next); then compound 1.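

In this assay, methyl to (naphthalen-1-yl)methyl gives a number 59 percentage points lower from compound 1 to compound 4 (beyond the scatter), so naphthalen-1-yl on this saturated chain carbon bound to an aromatic carbon is poorly tolerated, at least in the core of compound 1. For the compounds shown here, the only earlier step, between two aromatic groups at a different attachment, gave no sign of a fall of this size. No available evidence bears on the reason for this fall. On these data alone, whether the fall is specific to naphthalen-1-yl or extends to smaller groups remains open. An unsubstituted phenyl, an ethyl chain or an aminomethyl group in place of the methyl would separate these cases.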